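Dimethyl Substitution on the Cyclohexenyl Ring of Compound 2

The source may report more compounds than this note shows. Statements on the series, on what has been measured and on what is new or still open speak of the compounds shown alone.

Measured in an assay on CHO cells for antagonist activity at transient receptor potential cation channel subfamily V member 1 (Homo sapiens), read by FLIPR and calcium flux; on this read-out lower numbers stand for stronger inhibition and higher numbers for weaker inhibition:
Compound 1 `CCCc1nc(C(F)(F)F)ccc1CNC(=O)C(C)c1ccc(NS(C)(=O)=O)c(F)c1`: 22.7 nM
Compound 2 `CC(C(=O)NCc1ccc(C(F)(F)F)nc1C1=CCCCC1)c1ccc(NS(C)(=O)=O)c(F)c1`: 0.7 nM

Going by the values given here, compound 2 holds the lower of the two numbers; the only measured step is a 32-fold lower number from compound 1 to compound 2 (1.51 log units; beyond the scatter), a large one. Compound 3 `CC(C(=O)NCc1ccc(C(F)(F)F)nc1C1=CCC(C)(C)CC1)c1ccc(NS(C)(=O)=O)c(F)c1` differs from compound 2 by 4,4-dimethylcyclohex-1-en-1-yl in place of cyclohex-1-en-1-yl on an aromatic carbon. That measured step concerns a different replacement and does not bear directly on adding two methyl groups to a ring that is kept. Among the compounds with values here, with no precedent, compound 3 is expected in this assay at 0.8 nM, in the range 0.3 nM to 2.5 nM. The expected step is a 1.1-fold higher number from compound 2 to compound 3 (0.06 log units; within the scatter), within the scatter.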

Compound 3, inhibition constant: 0.2 nM
The estimate for compound 3 lay 4.0-fold (0.60 log units) above the measured number; measured number below the stated range.
By their numbers in this assay, from the lowest: compound 3; then compound 2; then compound 1.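

In this assay, the ring on the aromatic carbon next to the ring nitrogen accepts two added methyl groups with a gain rather than a loss, giving a 3.5-fold lower number from compound 2 to compound 3 (0.54 log units; beyond the scatter). Measured against the propyl group, 4,4-dimethylcyclohex-1-en-1-yl gives a 110-fold lower number from compound 1 to compound 3 (2.05 log units; beyond the scatter). Nothing available accounts for this gain.

The compounds shown leave open whether both methyl groups are needed, since a single methyl group would separate their contributions. They also leave open how an ethyl group, a hydroxyl or an amine would compare in place of the two methyl groups.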